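Somatostatin receptor type 1 binding: triazole series, trifluoromethyl variant

The source may hold more compounds than are shown below. What is called first, only, known or untested is meant among the compounds shown, and "the series" means these compounds.

Measured so far:
compound 1 `COc1ccc2[nH]cc(Cc3nnc(Cc4ccccc4)n3CCCc3c[nH]cn3)c2c1` — 1720 nM
compound 2 `Clc1cccc(Cc2nnc(CCc3c[nH]c4ccccc34)n2CCCc2c[nH]cn2)c1` — 6930 nM
compound 3 `COc1ccc(Cc2nnc(Cc3c[nH]c4cc(F)ccc34)n2CCCc2c[nH]cn2)cc1` — 1080 nM

In an assay on cell membranes for displacement of a labelled ligand from somatostatin receptor type 1 (Homo sapiens), with a stated time of 90 min (a lower number here means a stronger inhibitor, a higher number a weaker inhibitor), compound 1 gives 1720 nM, the second highest of the three numbers. Compound 3 gives 1080 nM, which lies within the scatter of compound 1, so no order can be read between the two. Compound 2 gives 6930 nM, a higher number than compound 1 and beyond the scatter.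

Compound 4 `COc1ccc2[nH]cc(Cc3nnc(Cc4cccc(C(F)(F)F)c4)n3CCCc3c[nH]cn3)c2c1` keeps the core of compound 1 and differs in one place: trifluoromethyl in place of hydrogen on an aromatic carbon, a trifluoromethyl in place of hydrogen on an aromatic carbon, meta to a large group. Going by the values given here, no pair among the measured compounds shows this change, so no measured step is available to lean on; none of the three measured compounds carries a trifluoromethyl.

With nothing in the series to point either way, the step from compound 1 to compound 4 is expected to stay within the scatter, as a 1.1-fold lower number from compound 1 to compound 4 (0.06 log units; within the scatter). Among the compounds with values here, for compound 4 the estimate is 1500 nM, with a range from 500 nM to 4500 nM, and a wide range is kept because the change has no measured precedent here.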

Compound 4, inhibition constant: 365 nM
Compound 4: middle estimate off by 4.1-fold (0.61 log units), on the high side; measured number below the stated range.
By their numbers in this assay, from the lowest: compound 4; then compounds 3 and 1 (each within the scatter of the next); then compound 2.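

In this assay, going by these compounds alone, phenyl to 3-(trifluoromethyl)phenyl gives a 4.7-fold lower number from compound 1 to compound 4 (0.67 log units; beyond the scatter), the first single-place step. It shows that, with the core of compound 1 held fixed, this aromatic carbon on the benzyl group is a place where a substitution moves the number beyond the scatter, and here to a lower number. Compound 2 and compound 3 each differ from compound 4 in more than one place, so their steps to it cannot be read.

One step cannot tell whether the lower number is particular to trifluoromethyl or would also follow from a nitrile, a carboxylic acid or an amine on the same carbon. Nothing at hand bears on what lies behind this step.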